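The source may report more compounds than this note shows. Statements on the series, on what has been measured and on what is new or still open speak of the compounds shown alone.

Working notes on the series. Compound 1 `O=S(=O)(Nc1ccc(-c2nc3ccccc3o2)cc1)c1ccccc1O` and compound 3 `O=S(=O)(Nc1ccc(-c2nc3ccccc3o2)cc1)c1ccc(Cl)cc1` share the same core and differ only in the aryl group on the sulfonyl sulfur. Compound 2 `C=Cc1ccc(S(=O)(=O)Nc2ccc3oc(-c4ccccc4)nc3c2)cc1` is the other measured member of the set and is not a single-point neighbour of either.

In an ADME assay on HEK293 cells (Homo sapiens) for cytotoxicity, read by resazurin assay, with a stated time of 48 h (on this read-out higher numbers stand for lower toxicity in this test and lower numbers for higher toxicity in this test), compound 1 reaches only the limit of the test, reported as > 100000 nM, so no number is known for it. This is the limit of > 100000 nM in this assay, at which 1 of the 2 values shown sits. In this assay compound 2 gives 53000 nM, a number inside the measured range. Between these two compounds no single step is defined, and the two values show only that compound 1 sits at the limit while compound 2 does not.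

The change from compound 1 to compound 3 is 4-chlorophenyl in place of 2-hydroxyphenyl on a sulfonyl sulfur. With no measured step of this kind in the set, the step from compound 1 to compound 3 is expected as an at least 1.6-fold lower number from compound 1 to compound 3 (0.22 log units; that floor lies within the scatter), a small move toward higher toxicity that may not exceed the usual scatter. In this assay compound 3 is estimated at 60000 nM, with a range from 20000 nM to 150000 nM.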

Compound 3, half-maximal cytotoxic concentration: > 100000 nM
Compound 3: a limit, no number; the forecaster's own chance of this, stated with the estimate: 35%; middle value at least 1.6-fold (0.22 log units) away from the limit.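

In this assay compound 3 gives > 100000 nM as a limit and not a number. For the compounds shown here, with compound 1 also at a limit, no step from compound 1 to compound 3 can be read: the limit of > 100000 nM in this assay, at which 2 of the 3 values shown sit. The compounds shown leave open whether 4-chlorophenyl in place of 2-hydroxyphenyl on a sulfonyl sulfur changes this read-out at all.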